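The source may hold more compounds than are shown below. What is called first, only, known or untested is meant among the compounds shown, and "the series" means these compounds.

Three compounds have been measured in a functional assay on HeLa cells (Homo sapiens) for cytotoxicity, read by CCK-8 assay, with a stated time of 24 h; a higher number here means a weaker inhibitor, a lower number a stronger inhibitor:

Compound 1, `C=C1CCC(c2csc(/C=C(\C)C(N)=O)c2)CC1`, gives 5010 nM.
Compound 2, `C/C(=C\c1cc(-c2ccccc2)co1)C(N)=O`, gives 3280 nM.
Compound 3, `C/C(=C\c1cc(-c2ccc(C)cc2)co1)C(N)=O`, gives 12000 nM.

Compound 3 thus has the highest number of the three, meaning it is the weakest inhibitor among them; its nearest neighbour is compound 1 and its furthest is compound 2, and both gaps lie beyond the usual scatter.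

Compound 4, `C/C(=C\c1cc(-c2ccc(F)cc2)co1)C(N)=O`, differs from compound 3 in one place: fluoro in place of methyl on an aromatic carbon. Within the data shown here, the only measured step at this position is a 3.7-fold higher number from compound 2 to compound 3 (0.56 log units; beyond the scatter), where a methyl group replaced a hydrogen. Among the measured compounds shown here, no measured step shows a fluoro group at that place, so the size of the coming change cannot be read directly from the data. With the methyl group leaving, a return toward the value of compound 2 is plausible, but a small group still remains there. The expected step is therefore a 1.7-fold lower number from compound 3 to compound 4 (0.23 log units; within the scatter), a modest lowering of the number that may not exceed the scatter. Compound 4 is estimated at 7000 nM, within a range from 3000 nM to 18000 nM.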

Compound 4, half-maximal inhibitory concentration: 11800 nM
The estimate for compound 4 lay 1.7-fold (0.23 log units) below the measured number; low and high end bracket the measured number.
By their numbers in this assay, from the lowest: compounds 2 and 1 (each within the scatter of the next); then compounds 4 and 3 (each within the scatter of the next).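

In this assay, fluoro in place of methyl gives a 1.0-fold lower number from compound 3 to compound 4 (0.01 log units; within the scatter), so at this position on the aromatic ring the two groups cannot be told apart. Compared with hydrogen, fluoro gives a 3.6-fold higher number from compound 2 to compound 4 (0.56 log units; beyond the scatter), and methyl gives a 3.7-fold higher number from compound 2 to compound 3 (0.56 log units; beyond the scatter), so the higher number is no longer tied to methyl alone: both groups raise it beyond the scatter. No measurement available here offers a reason for this shared rise.

The compounds shown leave open whether an amine, a carboxylic acid or a longer chain such as ethoxy at this place would also raise the number. They also leave open whether almost any group here would do so, or only these two.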